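The source may report more compounds than this note shows. Statements on the series, on what has been measured and on what is new or still open speak of the compounds shown alone.

The compounds measured so far:
- compound 1, `O=c1c(CCO)c(-c2ccccc2Cl)c2cc(Cl)ccc2n1-c1ccccc1`; in an ADME assay on HepG2 2.2.15 cells (Homo sapiens) for cytotoxicity (on this read-out higher numbers stand for lower toxicity in this test and lower numbers for higher toxicity in this test), compound 1 gives 26000 nM.
- compound 2, `O=c1c(CCO)c(-c2ccccc2Cl)c2cc(Cl)ccc2n1-c1c(F)cccc1F`; in this assay compound 2 is reported only as a limit, > 2300000 nM.
- compound 3, `CC(=O)N1CCC(C(=O)OCCc2c(-c3ccccc3Cl)c3cc(Cl)ccc3[nH]c2=O)CC1`; in this assay compound 3 gives 82000 nM.

Of the two plain numbers, compound 3 stands highest, with compound 1 as its nearest neighbour and the gap between them beyond the scatter. Compound 1 and compound 3 differ in more than one place, so nothing beyond their two values can be said of that pair.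

Among the compounds with values here, the one step that can be traced is an at least 88-fold higher number from compound 1 to compound 2 (1.94 log units; beyond the scatter). It concerns the group on the aromatic nitrogen, and the value of compound 2 is a limit of this assay, (the limit of > 2300000 nM in this assay, at which 1 of the 3 values shown sits). That step does not touch the ester side chain and so does not bear on the change toward compound 4.

Compound 4, `C/C=C(\C)C(=O)OCCc1c(-c2ccccc2Cl)c2cc(Cl)ccc2[nH]c1=O`, differs from compound 3 in that change: 1-methylprop-1-en-1-yl in place of 1-acetylpiperidin-4-yl on a carbonyl carbon. Within the data shown here, no measured step resembles it, so compound 4 is expected to give a number not beyond the scatter from compound 3, a 1.4-fold lower number from compound 3 to compound 4 (0.14 log units; within the scatter). Compound 4 is estimated at 60000 nM, between 20000 nM and 180000 nM.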

Compound 4, half-maximal cytotoxic concentration: 350000 nM
The estimate for compound 4 lay 5.8-fold (0.77 log units) below the measured number, outside the stated range (above it).
By their numbers in this assay, from the lowest: compound 1; then compound 3; then compound 4. At a limit, above all of these: compound 2.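

In this assay the group on the carbonyl carbon of the ester side chain proves able to move the number, with a 4.3-fold higher number from compound 3 to compound 4 (0.63 log units; beyond the scatter) when 1-methylprop-1-en-1-yl replaces 1-acetylpiperidin-4-yl. Within the data shown here, the earlier traced step concerned only the group on the aromatic nitrogen, so this is the first sign that a second place on these compounds also matters in this test, although it rests on a single pair. It also shows that the higher of the two ester numbers does not depend on keeping the six-membered ring or the acetyl group, while this one pair cannot say which part of the exchange counts.

From the compounds shown here alone, whether a saturated butyl chain, a piperidine carrying a free amine, or an amide in place of the ester would side with compound 3 or compound 4 stays open, as does whether the same exchange would carry over to a compound with 2,6-difluorophenyl on the aromatic nitrogen. Nothing measured among these compounds gives a reason for the rise that comes with this change.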